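Methoxy next to the phenol in the cyclohexanone series

The source may report more compounds than this note shows. Statements on the series, on what has been measured and on what is new or still open speak of the compounds shown alone.

Two compounds of this series have numbers in a functional assay on HL-60 cells (Homo sapiens) for cytotoxicity; a lower number here means that less compound is tolerated, a higher number that more compound is tolerated. Compound 1 `O=C1/C(=C/c2ccc(O)cc2)CCC/C1=C\c1ccc([N+](=O)[O-])cc1` gives 4400 nM in this assay, the highest of the two numbers. Among the compounds with values here, compound 2 `COc1cc(/C=C2\Cc3ccccc3/C(=C\c3ccc([N+](=O)[O-])cc3)C2=O)ccc1O` gives 950 nM in this assay, a lower number than compound 1, a gap beyond the scatter; the two differ in their core as well as in the methoxy, so no single step links them.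

Compound 3 `COc1cc(/C=C2\CCC/C(=C\c3ccc([N+](=O)[O-])cc3)C2=O)ccc1O` has not yet been measured. It differs from compound 1 by methoxy in place of hydrogen on an aromatic carbon, ortho to a hydroxy group; cut one bond further out, 4-hydroxyphenyl becomes 4-hydroxy-3-methoxyphenyl. Within the data shown here, no step between measured compounds shows this change alone. The expectation is a small step toward a lower number, at the edge of the scatter, because compound 2, which carries the methoxy, gives 950 nM. For compound 3 the estimated value is 3000 nM, between 1200 nM and 7500 nM, an expected step of a 1.5-fold lower number from compound 1 to compound 3 (0.17 log units; within the scatter).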

Compound 3, half-maximal cytotoxic concentration: 3400 nM
For compound 3 the middle estimate is 1.1-fold (0.05 log units) below the measured one, and the stated range covers the measured number.
By their numbers in this assay, from the lowest: compound 2; then compounds 3 and 1 (each within the scatter of the next).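

In this assay, methoxy in place of hydrogen on an aromatic carbon, ortho to a hydroxy group, gives a 1.3-fold lower number from compound 1 to compound 3 (0.11 log units; within the scatter), so on the core of compound 1 the change from 4-hydroxyphenyl to 4-hydroxy-3-methoxyphenyl cannot be told apart from no change. Within the data shown here, this is the first step that isolates the methoxy, and it gives no support for reading the gap between compound 1 and compound 2 as an effect of the methoxy; that gap still combines the methoxy with the difference in core. No measurement at hand explains the result.

On these data alone, whether an ethoxy group or an amine at this place would move the number beyond the scatter stays open. Also open, as far as these compounds go, is the size of the same methoxy step on the core of compound 2.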